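The source may hold more compounds than are shown below. What is called first, only, known or untested is meant among the compounds shown, and "the series" means these compounds.

In a toxicity assay on Huh-7.5 cells (Homo sapiens) for inhibition, read by MTT assay, with a stated time of 96 h (a lower number here means that less compound is tolerated, a higher number that more compound is tolerated), compound 2 `CCCOc1ccc(C(=O)Nc2ccc(OC)cc2)cc1NC(=O)CC` gives 106000 nM. Among the compounds with values here, the only other measured compound, compound 1 `COc1ccc(NC(=O)c2ccc(OCCCN(C)C)c([N+](=O)[O-])c2)cc1`, gives 127000 nM, and the two values lie within the scatter of each other. Compound 2 therefore stands level with compound 1 on the numbers available.

Compound 3 `CCC(=O)Nc1cc(C(=O)Nc2ccc(OC)cc2)ccc1OCCCN(C)C` has not yet been measured. It differs from compound 2 by one change: dimethylamino in place of hydrogen on a saturated chain carbon, three bonds along the chain from an oxygen on an aromatic ring. This places dimethylamino in place of hydrogen on a saturated chain carbon, three bonds along the chain from an oxygen on an aromatic ring, so that propyl becomes 3-(dimethylamino)propyl.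

Within the data shown here, no measured pair isolates this change, so its size in this assay cannot be read directly. The closest evidence is compound 1, which carries the same 3-(dimethylamino)propyl chain, differs elsewhere on the core, and gives 127000 nM. On that basis, no step beyond the scatter is expected in either direction. The expected 1.1-fold lower number from compound 2 to compound 3 (0.03 log units; within the scatter) is correspondingly small. For compound 3, the half-maximal cytotoxic concentration is estimated at 100000 nM, with an expected range of 45000 nM to 200000 nM.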

Compound 3, half-maximal cytotoxic concentration: 154000 nM
The estimate for compound 3 lay 1.5-fold (0.19 log units) below the measured number; the measured number falls inside the stated range.
By their numbers in this assay, from the lowest: compounds 2, 1 and 3 (each within the scatter of the next).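

In this assay, within the data shown here, compounds 2 and 3 form the first pair that isolates this change: with the rest of the structure held constant, dimethylamino in place of hydrogen on a saturated chain carbon, three bonds along the chain from an oxygen on an aromatic ring, turns propyl into 3-(dimethylamino)propyl and gives a 1.5-fold higher number from compound 2 to compound 3 (0.16 log units; within the scatter) for the step. At this position and on this core, the change therefore leaves the half-maximal cytotoxic concentration without a step beyond the scatter. With the 3-(dimethylamino)propyl chain held constant, compounds 1 and 3 add a second isolated change, propanoylamino in place of nitro on an aromatic carbon, and this gives a 1.2-fold higher number from compound 1 to compound 3 (0.08 log units; within the scatter) for the step, so neither single change separates the compounds in this assay, and no measurement is available that could account for either step.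

The compounds shown leave open whether a different amine at the end of the chain, such as a pyrrolidine or a morpholine, or a carboxylic acid in place of dimethylamino would also stay within the scatter. They also leave open whether the same holds for a shorter chain such as 2-(dimethylamino)ethyl or for a longer chain carrying dimethylamino.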